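This account rests on a few compounds, and the source may have more. Where it says the series, first, only, none or still open, it means among the compounds named here.

The series shares the core of compound 2 `Cc1nc(N)sc1CCCN/C(N)=N/C(=O)NCC(C)CC1CCCCC1`, an aminothiazole-bearing guanidine-acylurea. In a functional assay on HEK293T cells for agonist activity at histamine H2 receptor (Homo sapiens), read by beta-arrestin recruitment (on this read-out lower numbers stand for an effect already at smaller amounts and higher numbers for an effect only at larger amounts of compound), compound 2 gives 302 nM; compound 1 `Cc1nc(N)sc1CCCN/C(N)=N/C(=O)NCC(C)CCc1ccccc1` gives 355 nM, and the two numbers lie within the scatter of each other, so neither stands apart. Within the data shown here, the one measured step, a 1.2-fold lower number from compound 1 to compound 2 (0.07 log units; within the scatter), shows that a saturated ring in place of an aromatic ring at this chain position left the read-out unchanged beyond the scatter.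

Compound 3 `Cc1ccc(CC(C)CNC(=O)/N=C(\N)NCCCc2sc(N)nc2C)cc1` differs from compound 2 by 4-methylphenyl in place of cyclohexyl on a saturated chain carbon, three bonds along the chain from an amide-type nitrogen; seen one bond further out it reads cyclohexylmethyl to 4-methylbenzyl. Among the measured compounds shown here, only the step from compound 1 to compound 2 bears on this change, and it lay within the scatter. For compound 3 no step beyond the scatter is therefore expected in this assay, and the estimated step is a 1.1-fold higher number from compound 2 to compound 3 (0.03 log units; within the scatter). Compound 3 is expected at 320 nM, with a range of 150 nM to 700 nM.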

Compound 3, half-maximal effective concentration: 132 nM
The estimate for compound 3 lay 2.4-fold (0.38 log units) above the measured number; measured number below the stated range.
By their numbers in this assay, from the lowest: compound 3; then compounds 2 and 1 (each within the scatter of the next).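

In this assay, among these compounds, 4-methylphenyl gives the first changes at this position that lie beyond the scatter, a 2.3-fold lower number from compound 2 to compound 3 (0.36 log units; beyond the scatter) and a 2.7-fold lower number from compound 1 to compound 3 (0.43 log units; beyond the scatter), so the saturated chain carbon three bonds along the chain from an amide-type nitrogen does respond to the group it carries, if only modestly. An aromatic ring alone does not account for this, as compound 1 also carries one and stays within the scatter of compound 2. No available measurement explains the lower number of compound 3.

Compound 3 brings the aromatic ring and the methyl together, so the compounds shown cannot assign the step to either one. Plain phenyl would separate the two, while 4-chlorophenyl or 4-methoxyphenyl would test whether the methyl can be exchanged.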